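A few compounds are considered here, and "the series" means these few. Any claim that something is new, unique, unknown or untested is made for them only; others in the source may bear on it.

Among the compounds with values here, in a functional assay on A549 cells (Homo sapiens) for inhibition, read by MTT assay, with a stated time of 48 h (a higher number here means a weaker inhibitor, a lower number a stronger inhibitor), compound 2 (`COc1ccc(OC)c(C(c2c[nH]c3ccc(Br)cc23)c2c[nH]c3ccc(Br)cc23)c1`) gives 10000 nM, the lower of the two numbers so far, while compound 1 (`COc1ccc(C(c2c[nH]c3ccc(Br)cc23)c2c[nH]c3ccc(Br)cc23)c(OC)c1`) gives 100000 nM. Compound 3 (`Clc1ccc(C(c2c[nH]c3ccc(Br)cc23)c2c[nH]c3ccc(Br)cc23)cc1`) carries 4-chlorophenyl in place of 2,5-dimethoxyphenyl on a saturated chain carbon bound to two aromatic carbons. Within the data shown here, only one measured step bears on this place: a 10-fold lower number from compound 1 to compound 2 (1.00 log units; beyond the scatter). That modest step exchanges one dimethoxyphenyl for another, so the data give no direction for a chlorophenyl. In this assay the expected outcome is no change at the digits printed from compound 2 to compound 3 (within the scatter), with either direction open. For compound 3 the estimated value is 10000 nM, within a range of 2500 nM to 50000 nM.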

Compound 3, half-maximal inhibitory concentration: 8500 nM
Estimate against measurement, compound 3: 1.2-fold (0.07 log units) above, and the stated range covers the measured number.
By their numbers in this assay, from the lowest: compounds 3 and 2 (each within the scatter of the next); then compound 1.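

In this assay, 4-chlorophenyl on a saturated chain carbon bound to two aromatic carbons gives a 1.2-fold lower number from compound 2 to compound 3 (0.07 log units; within the scatter), so this place holds its value with a group carrying no hydrogen-bond acceptors. The methoxy groups are therefore not required for the level of compound 2. The same group gives a 12-fold lower number from compound 1 to compound 3 (1.07 log units; beyond the scatter), which leaves 2,4-dimethoxyphenyl alone apart from the other two groups.

No measurement shown gives a reason for this gap. Still open, on these data alone, is whether unsubstituted phenyl, or a phenyl bearing an amine or a carboxylic acid, keeps this level.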